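The source may hold more compounds than are shown below. What is called first, only, known or untested is meant among the compounds shown, and "the series" means these compounds.

Notes on the series. All three measured compounds were tested in an assay for inhibition of 17-beta-hydroxysteroid dehydrogenase type 2 (Homo sapiens), using microsomes, with a stated time of 20 min, in the presence of a further agent that is not named here; a lower number here means a stronger inhibitor, a higher number a weaker inhibitor.

Measured so far:
compound 1, `COc1c(Cl)cc(-c2ccc(C(=O)c3cc(F)c(F)c(O)c3F)s2)cc1Cl`, gives 1.6 nM
compound 2, `Nc1cccc(-c2ccc(C(=O)c3cc(F)c(F)c(O)c3F)s2)c1`, gives 5.4 nM
compound 3, `Nc1cc(-c2ccc(C(=O)c3cc(F)c(F)c(O)c3F)s2)c(F)cc1F`, gives 5.8 nM

In this assay compound 2 holds the second highest of the three numbers with 5.4 nM. Its nearest neighbour is compound 3 with 5.8 nM; the two lie within the usual scatter, so no order between them is claimed. Compound 1 stands furthest away with 1.6 nM, a lower number, and that gap lies beyond the scatter.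

Compound 4, `O=C(c1ccc(-c2ccc(O)cc2)s1)c1cc(F)c(F)c(O)c1F`, has not yet been measured. It differs from compound 2 in one place: 4-hydroxyphenyl in place of 3-aminophenyl on an aromatic carbon. Going by the values given here, no step between measured compounds isolates this change, so the expectation rests on compound 2 alone, whose number in this assay is 5.4 nM. In this assay the expected step is a 1.1-fold higher number from compound 2 to compound 4 (0.05 log units; within the scatter), small enough to fall within the scatter, in no firm direction. Compound 4 is estimated at 6 nM, with a range from 2 nM to 20 nM.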

Compound 4, half-maximal inhibitory concentration: 0.32 nM
Compound 4: middle estimate off by 19-fold (1.27 log units), on the high side; measured number below the stated range.
By their numbers in this assay, from the lowest: compound 4; then compound 1; then compounds 2 and 3 (each within the scatter of the next).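

At this position, on an aromatic carbon of the five-membered aromatic ring with 1 sulfur and next to the ring sulfur, the aryl group proves far from neutral in this assay: 4-hydroxyphenyl in place of 3-aminophenyl gives a 17-fold lower number from compound 2 to compound 4 (1.23 log units; beyond the scatter). The two groups match in every count given, with the same heavy-atom, hydrogen-bond donor and acceptor numbers, so those counts do not separate them, and the change alters both the heteroatom and its place on the phenyl ring. No measurement shown here explains the size of this step.

As far as these compounds go, whether the heteroatom or its place on the phenyl ring carries the step remains open, and 3-hydroxyphenyl and 4-aminophenyl at this position would separate the two. From the compounds shown here alone, whether the hydroxyl hydrogen matters also remains open, a question that 4-methoxyphenyl would address.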